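The source may hold more compounds than are shown below. What is called first, only, known or untested is meant among the compounds shown, and "the series" means these compounds.

Measured compounds:
compound 1, `COC(=O)c1ccc(NCc2cncn2Cc2ccc(C#N)cc2)cc1-c1ccccc1`: > 10000 nM
compound 2, `Cc1cccc(-c2cc(NCc3cncn3Cc3ccc(-c4ccccc4)cc3)ccc2-c2nc3ccccc3s2)c1C`: > 1000 nM

In a toxicity assay on NIH3T3 cells (Mus musculus) for cytotoxicity, read by resazurin assay (a lower number here means that less compound is needed, a higher number that more compound is needed for the effect), compound 1 gives only a limit, > 10000 nM. Compound 2 likewise gives only a limit in this assay, > 1000 nM. Compound 1 thus stands at the limit of > 10000 nM in this assay, at which 1 of the 2 values shown sits, and neither result is a number. Compound 3, `COC(=O)c1ccc(NCc2cncn2Cc2ccccc2[N+](=O)[O-])cc1-c1ccccc1`, is not yet measured; it differs from compound 1 by 2-nitrophenyl in place of 4-cyanophenyl on a saturated chain carbon bound to an aromatic nitrogen. Among the measured compounds shown here, no step between two measured compounds exists here, so the size of this change cannot be read from the data. The step that the limit leaves unreadable from compound 1 to compound 3 is expected to stay within the scatter. Compound 3 is estimated at 15000 nM, between 5000 nM and 50000 nM, and most likely reported again only as a limit.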

Compound 3, half-maximal effective concentration: 10000 nM
Estimate against measurement, compound 3: 1.5-fold (0.18 log units) above; low and high end bracket the measured number.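

In this assay, among the compounds shown here, compound 3 gives a measured number (10000 nM), so 2-nitrophenyl in place of 4-cyanophenyl on a saturated chain carbon bound to an aromatic nitrogen yields the first value here that is not a limit. Compound 1 gives > 10000 nM in the same assay, and this is a limit, not a number. The step therefore reads (a number no higher from compound 1 to compound 3 (the limit leaves the size open)), and its size cannot be read.

Nothing measured here accounts for the value of compound 3. Going by these compounds, it remains open whether an aminobenzyl or carboxybenzyl group at this place would also give a number.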